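Swapping the hydroxyphenyl for a methylphenyl on a shared core

The compounds below may be only part of what the source reports. "The series", "measured", "known", "first", "only" and "open" are said of these compounds alone.

Measured so far:
compound 1, `Cc1nc2c3ccccc3ccc2c2nc3c(ccc4ccccc43)c(-c3cccc([N+](=O)[O-])c3)c12`, 25500 nM
compound 2, `Cc1nc2c3ccccc3ccc2c2nc3c(ccc4ccccc43)c(-c3ccccc3Cl)c12`, 52500 nM
compound 3, `Cc1nc2c3ccccc3ccc2c2nc3c(ccc4ccccc43)c(-c3ccc(O)cc3)c12`, 14200 nM

In a functional assay on AGS cells (Homo sapiens) for cytotoxicity, read by MTT assay, with a stated time of 48 h (a higher number here means a weaker inhibitor, a lower number a stronger inhibitor), compound 3 gives the lowest of the three numbers. Its nearest neighbour is compound 1, a step of a 1.8-fold lower number from compound 1 to compound 3 (0.25 log units; within the scatter); the furthest is compound 2, a step of a 3.7-fold lower number from compound 2 to compound 3 (0.57 log units; beyond the scatter), and between those two lies a 2.1-fold higher number from compound 1 to compound 2 (0.31 log units; beyond the scatter).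

Compound 4, `Cc1ccc(-c2c3ccc4ccccc4c3nc3c2c(C)nc2c4ccccc4ccc32)cc1`, differs from compound 3 by methyl in place of hydroxy on an aromatic carbon. Going by the values given here, no measured step replaces the hydroxy with a methyl, so the three aryl swaps are the only guide, and together they span a modest range. Compound 4 is therefore expected to give a modestly higher number, a step of a 1.5-fold higher number from compound 3 to compound 4 (0.19 log units; within the scatter), estimated at 22000 nM with a range from 9000 nM to 55000 nM.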

Compound 4, half-maximal inhibitory concentration: > 80000 nM
Compound 4 was reported as a limit (the forecaster's own chance of this, stated with the estimate: 5%); middle value at least 3.6-fold (0.56 log units) from the limit.
By their numbers in this assay, from the lowest: compounds 3 and 1 (each within the scatter of the next); then compound 2. At a limit, above all of these: compound 4.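

In this assay compound 4 is reported only as a limit, not a number: the limit of > 80000 nM in this assay, at which 1 of the 4 values shown sits. Going by these compounds alone, on the ring carbon para to a large group, methyl in place of hydroxy gives an at least 5.6-fold higher number from compound 3 to compound 4 (0.75 log units; beyond the scatter) and so is a larger step than any among the earlier compounds, showing that this single group matters here. Against the other aryl groups, the 4-methylphenyl gives an at least 3.1-fold higher number from compound 1 to compound 4 (0.49 log units; beyond the scatter) and an at least 1.5-fold higher number from compound 2 to compound 4 (0.18 log units; that floor lies within the scatter), so only the second comparison remains unresolved.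

As far as these compounds go, what an amine or a carboxylic acid in the place of the hydroxy would give stays open. From the compounds shown here alone, the true value of compound 4 also stays open.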